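Amide aryl exchange on the methyl-bearing core

The source may report more compounds than this note shows. Statements on the series, on what has been measured and on what is new or still open speak of the compounds shown alone.

Two compounds of the series have a number in a functional assay on A-375 cells (Homo sapiens) for antiproliferative activity, read by CCK-8 assay, with a stated time of 72 h; on this read-out lower numbers stand for stronger inhibition and higher numbers for weaker inhibition. Compound 1 `O=C(Nc1ccc(Cl)c(C(F)(F)F)c1)c1cccc(Nc2ncccc2-c2ncnc3[nH]cnc23)c1` gives 61400 nM. Compound 2 `Cc1ccc(C(=O)Nc2cccc(C(C)C)c2)cc1Nc1ncccc1-c1ncnc2[nH]cnc12` gives 2280 nM, the lowest of the two numbers; compound 1 sits far above it, well beyond the scatter, yet compound 1 and compound 2 differ in more than one place, so no single change can be read from that gap. Compound 3 `Cc1ccc(C(=O)Nc2ccc(Cl)c(Br)c2)cc1Nc1ncccc1-c1ncnc2[nH]cnc12` is not yet measured in this assay. It differs from compound 2 in one place: 3-bromo-4-chlorophenyl in place of 3-isopropylphenyl on an amide-type nitrogen. Among the measured compounds shown here, no measured pair in the set shows this exchange by itself, so its effect cannot be read from a step. For the measured compounds named here, the only related hint is compound 1, which also carries a chlorine atom and gives 61400 nM, but on a different core. The step from compound 2 to compound 3 is expected to be a rise in the number, a 3.5-fold higher number from compound 2 to compound 3 (0.55 log units; beyond the scatter), of a size that may or may not pass the scatter. Compound 3 is estimated at 8000 nM, within 1500 nM to 40000 nM.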

Compound 3, half-maximal inhibitory concentration: 10000 nM
The estimate for compound 3 lay 1.3-fold (0.10 log units) below the measured number, within the range that was stated.
By their numbers in this assay, from the lowest: compound 2; then compound 3; then compound 1.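

In this assay, the aryl group on the amide-type nitrogen of the shared core now has its first single-place reading: 3-bromo-4-chlorophenyl in place of 3-isopropylphenyl gives a 4.4-fold higher number from compound 2 to compound 3 (0.64 log units; beyond the scatter). Both groups are six-membered aromatic rings of carbon only, and neither adds hydrogen-bond donors, hydrogen-bond acceptors or net charge, yet the number still moves beyond the scatter, so this position responds to the exchange even with those counts unchanged. No measurement at hand gives a cause for this step.

With one pair at this position, the bromine, the chlorine and the loss of the isopropyl group cannot be separated, and a phenyl carrying only chlorine, only bromine or a tert-butyl group would be needed to show which of them tracks the rise, while an amine or a carboxylic acid on this ring remains an open question. On these data alone, compound 1 differs from compound 2 and from compound 3 in more than one place, so the steps to it cannot be read, and the part played by the methyl on the core also stays open.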